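Isopropyl for hydroxyethyl on a second terpenoid quinone core

The compounds below may be only part of what the source reports. "The series", "measured", "known", "first", "only" and "open" are said of these compounds alone.

Compound 1, `C=C1[C@H](C)CCC[C@]1(C)CC/C(C)=C/CC1=C(O)C(=O)C=C(N[C@H](C(=O)O)[C@H](C)O)C1=O`, is compared in an ADME assay on L1210 cells (Mus musculus) for cytotoxicity, with a stated time of 48 h; a lower number here means a stronger inhibitor, a higher number a weaker inhibitor. In this assay compound 1 reaches only the limit > 10 ug/mL. Compound 2, `C=C1[C@H](C)CCC[C@]1(C)CC/C(C)=C/CC1=C(O)C(=O)C=C(N[C@H](C(=O)O)C(C)C)C1=O`, differs by isopropyl in place of 1-hydroxyethyl on a saturated chain carbon bound to an amine nitrogen and a carbonyl carbon, and in this assay compound 2 gives 4.4 ug/mL. That change produced an at least 2.2-fold lower number from compound 1 to compound 2 (0.35 log units; beyond the scatter), a step that is read only as a bound, due to the limit of > 10 ug/mL in this assay, at which 2 of the 3 values shown sit. Compound 3, `CC1=CCC[C@](C)(CC/C(C)=C/CC2=C(O)C(=O)C=C(N[C@H](C(=O)O)[C@H](C)O)C2=O)[C@@H]1C`, carries the other core, the difference being (a group of 9 heavy atoms (9 carbon; one six-membered non-aromatic ring of carbon only) in place of a group of 9 heavy atoms (9 carbon; one six-membered non-aromatic ring of carbon only), on a saturated chain carbon, two bonds along the chain from a double-bonded chain carbon). In this assay compound 3 likewise reaches only the limit > 10 ug/mL. Compound 4, `CC1=CCC[C@](C)(CC/C(C)=C/CC2=C(O)C(=O)C=C(N[C@H](C(=O)O)C(C)C)C2=O)[C@@H]1C`, differs from compound 3 by isopropyl in place of 1-hydroxyethyl on a saturated chain carbon bound to an amine nitrogen and a carbonyl carbon, the same change as from compound 1 to compound 2 at the same place. The step is expected to be an at least 2.0-fold lower number from compound 3 to compound 4 (0.30 log units; that floor lies within the scatter), resting on the measured change from compound 1 to compound 2 and on compound 2 at 4.4 ug/mL. Compound 4 is therefore estimated at 5 ug/mL, between 2.5 ug/mL and 10 ug/mL.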

Compound 4, half-maximal inhibitory concentration: 3.4 ug/mL
Beside the measured number, compound 4's estimate is 1.5-fold (0.17 log units) above it; measured number inside the range.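

In this assay, isopropyl in place of 1-hydroxyethyl also lowers the number on the core of compound 3, with an at least 2.9-fold lower number from compound 3 to compound 4 (0.46 log units; beyond the scatter), so the direction of the change carries from one core to the other, but the two steps cannot be shown to match in size: the same change on two cores in this assay, an at least 2.2-fold lower number (0.35 log units; beyond the scatter) from compound 1 to compound 2 and an at least 2.9-fold lower number (0.46 log units; beyond the scatter) from compound 3 to compound 4; the limit leaves it open whether they differ. Neither step has an exact size, and the step between compound 1 and compound 3 cannot be read, due to the assay limit reached by both hydroxyethyl compounds: the limit of > 10 ug/mL in this assay, at which 2 of the 4 values shown sit. The two isopropyl compounds stay within the scatter of each other, with a 1.3-fold lower number from compound 2 to compound 4 (0.11 log units; within the scatter), so these two cores cannot be told apart when they carry isopropyl.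

From the compounds shown here alone, whether a longer chain, an amine or a second carboxylic acid in place of isopropyl would give a lower number remains open. Going by these compounds, it also remains open whether the change would carry to a third core.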